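Replacing an aryl amide with a small ring amine

This account rests on a few compounds, and the source may have more. Where it says the series, first, only, none or still open, it means among the compounds named here.

Measured compounds in an assay on U2OS cells for inhibition of secreted frizzled-related protein 1 (Homo sapiens), read by a luciferase reporter, with a stated time of 18 h; a lower number here means that less compound is needed, a higher number that more compound is needed for the effect:
- compound 1 `O=C(c1cccc(Cl)c1)N1CCC(NS(=O)(=O)c2cc(S(=O)(=O)c3ccccc3)ccc2C(F)(F)F)CC1` gives 870 nM
- compound 2 `CN(C)c1ccc(C(=O)N2CCC(NS(=O)(=O)c3cc(S(=O)(=O)c4ccccc4)ccc3C(F)(F)F)CC2)cc1` gives 190 nM
- compound 3 `CC(C)(C)OC(=O)N1CCC[C@H]1C(=O)N1CCC(NS(=O)(=O)c2cc(S(=O)(=O)c3ccccc3)ccc2C(F)(F)F)CC1` gives 60 nM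

The three compounds share one core and differ only in the group attached to the carbonyl carbon of the amide. Compound 2 stands second highest of the three numbers: its nearest neighbour is compound 3, which shows a 3.2-fold lower number from compound 2 to compound 3 (0.50 log units; beyond the scatter), and its furthest is compound 1, which shows a 4.6-fold lower number from compound 1 to compound 2 (0.66 log units; beyond the scatter).

The new compound is compound 4 `O=C([C@@H]1CCNC1)N1CCC(NS(=O)(=O)c2cc(S(=O)(=O)c3ccccc3)ccc2C(F)(F)F)CC1`. It differs from compound 2 by pyrrolidin-3-yl in place of 4-(dimethylamino)phenyl on a carbonyl carbon.

Among the compounds with values here, two measured steps bear on this. Moving from compound 1 to compound 2 gave a 4.6-fold lower number from compound 1 to compound 2 (0.66 log units; beyond the scatter), and moving from compound 2 to compound 3 gave a 3.2-fold lower number from compound 2 to compound 3 (0.50 log units; beyond the scatter); in the second of these, a group containing a pyrrolidine ring replaced an aromatic ring, and the number fell. Compound 4 also brings in a pyrrolidine ring, but without the tert-butoxycarbonyl group and attached at a different ring position, so the measured steps give only a loose guide. A modest step in either direction, or none beyond the scatter, is expected for a 1.1-fold higher number from compound 2 to compound 4 (0.02 log units; within the scatter). Compound 4 is therefore estimated at 200 nM, with a range from 50 nM to 800 nM.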

Compound 4, half-maximal effective concentration: 380 nM
The estimate for compound 4 lay 1.9-fold (0.28 log units) below the measured number; low and high end bracket the measured number.
By their numbers in this assay, from the lowest: compound 3; then compounds 2 and 4 (each within the scatter of the next); then compound 1.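

In this assay, an aromatic ring on the carbonyl carbon proves not to be required: pyrrolidin-3-yl in place of 4-(dimethylamino)phenyl gives a 2.0-fold higher number from compound 2 to compound 4 (0.30 log units; within the scatter) and so cannot be told apart from the aryl amide, while pyrrolidin-3-yl in place of 3-chlorophenyl gives a 2.3-fold lower number from compound 1 to compound 4 (0.36 log units; beyond the scatter) and is a real gain over that aryl group. A pyrrolidine ring alone is also not enough to reach the low number of compound 3, since pyrrolidin-3-yl in place of 1-(tert-butoxycarbonyl)pyrrolidin-2-yl gives a 6.3-fold higher number from compound 3 to compound 4 (0.80 log units; beyond the scatter) as the ring attachment changes and the tert-butoxycarbonyl group is lost in the same step. Nothing available explains any of these differences.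

Still open, going by these compounds, is which of those two changes matters more, a question that pyrrolidin-2-yl without the tert-butoxycarbonyl group, or pyrrolidin-3-yl carrying it, could settle. Also open, on these data alone, is how an open-chain amine such as aminomethyl, or a carboxylic acid, would fare on the same carbonyl carbon.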